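The source may report more compounds than this note shows. Statements on the series, on what has been measured and on what is new or still open speak of the compounds shown alone.

In an ADME assay on the whole organism (strain FVB) for pharmacokinetics, with Mus musculus as the target, read by LC-MS, at a dose of 30 mg/kg by the oral route (a higher number here means more compound in the circulation at the dose given, a lower number less compound in the circulation), two compounds sharing one core have been measured so far. Compound 1 `CC(C)(O)CN1CCC(Oc2ccc([C@H]3CC[C@]4(CC3)OOC3(O4)C4CC5CC(C4)CC3C5)cc2)CC1` gives 14200 ng.h/mL, and compound 2 `c1cc([C@H]2CC[C@]3(CC2)OOC2(O3)C3CC4CC(C3)CC2C4)ccc1OC1CCNCC1` gives 7200 ng.h/mL. These two numbers lie within the scatter of each other, so the data cannot separate them.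

Compound 3 `c1cc([C@H]2CC[C@]3(CC2)OOC2(O3)C3CC4CC(C3)CC2C4)ccc1OCC1CCNCC1` has not yet been measured. It differs from compound 2 by a single change: (piperidin-4-yl)methyl in place of piperidin-4-yl on an oxygen on an aromatic ring. In other words, (piperidin-4-yl)oxy becomes (piperidin-4-yl)methoxy.

Among the measured compounds shown here, the only measured step is a 2.0-fold lower number from compound 1 to compound 2 (0.29 log units; within the scatter). It lies in a different place, with hydrogen in place of 2-hydroxy-2-methylpropyl on an amine nitrogen in a ring, so it bears on the new change only indirectly. It does show that one substituent swap in this series stayed within the scatter. For the measured compounds named here, no measured step covers the new change itself, so the estimate starts from compound 2 at 7200 ng.h/mL.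

The estimated step is a 1.0-fold lower number from compound 2 to compound 3 (0.01 log units; within the scatter), and no step beyond the scatter is expected in this assay. Compound 3 is expected at about 7000 ng.h/mL, with an estimated range from 2500 ng.h/mL to 18000 ng.h/mL.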

Compound 3, area under the concentration-time curve: 4040 ng.h/mL
Estimate against measurement, compound 3: 1.7-fold (0.24 log units) above; measured number inside the range.
By their numbers in this assay, from the lowest: compounds 3, 2 and 1 (each within the scatter of the next, the first and the last beyond it).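

In this assay, among the compounds shown here, the first change at this position, (piperidin-4-yl)oxy to (piperidin-4-yl)methoxy on an oxygen on an aromatic ring, gives a 1.8-fold lower number from compound 2 to compound 3 (0.25 log units; within the scatter) and so leaves compound 2 and compound 3 inseparable by this measurement. The series also now holds its first step beyond the scatter, a 3.5-fold lower number from compound 1 to compound 3 (0.55 log units; beyond the scatter) and this modest step combines the loss of the 2-hydroxy-2-methylpropyl group with the new methyl link, two changes that each stayed within the scatter when read alone. Nothing measured here explains why the number differs between these compounds.

The compounds shown leave open whether a longer chain on that oxygen, or an open-chain amine in place of the piperidine ring, would give a step beyond the scatter. For the compounds shown here, they also leave open whether adding 2-hydroxy-2-methylpropyl to the ring nitrogen of compound 3 would produce a step like the one that separates compound 1 and compound 2 on the (piperidin-4-yl)oxy side.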